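This account rests on a few compounds, and the source may have more. Where it says the series, first, only, none or still open, it means among the compounds named here.

Of the compounds shown here, three built on one shared core have been measured in a functional assay on PC-3 cells (Homo sapiens) for cytotoxicity, read by MTT assay, with a stated time of 48 h; a lower number here means a stronger inhibitor, a higher number a weaker inhibitor. Compound 2 `COc1cc(-c2nnc3n2NC(c2ccco2)C(C(=O)c2ccc(F)cc2)S3)cc(OC)c1OC` gives 27700 nM. Compound 1 `COc1cc(-c2nnc3n2NC(c2ccco2)C(C(=O)c2ccc(Br)cc2)S3)cc(OC)c1OC` gives 36400 nM, and compound 3 `COc1cc(-c2nnc3n2NC(c2cccs2)C(C(=O)c2ccc(F)cc2)S3)cc(OC)c1OC` gives 27400 nM. Compound 2 thus stands among three numbers that all lie within the scatter of one another: the step of a 1.3-fold lower number from compound 1 to compound 2 (0.12 log units; within the scatter) and the step of a 1.0-fold lower number from compound 2 to compound 3 (0.00 log units; within the scatter) are both small.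

Compound 4 `COc1ccc(C(=O)C2Sc3nnc(-c4cc(OC)c(OC)c(OC)c4)n3NC2c2ccco2)cc1` has not yet been measured. It differs from compound 2 in one place: methoxy in place of fluoro on an aromatic carbon. The step that bears most on this change is the one on the same aromatic carbon, a 1.3-fold lower number from compound 1 to compound 2 (0.12 log units; within the scatter), which exchanged one halogen for another without moving the number beyond the scatter. For the measured compounds named here, no measured step exchanges a halogen for a methoxy group, so the data give no direct guide for that. With only a within-scatter step at this carbon to go on, compound 4 is expected to show a 1.0-fold higher number from compound 2 to compound 4 (0.00 log units; within the scatter), nothing beyond the scatter. The estimate for compound 4 in this assay is therefore 28000 nM, with a range from 12000 nM to 65000 nM.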

Compound 4, half-maximal inhibitory concentration: > 100000 nM
Compound 4 ended at the assay's limit (the forecaster's own chance of this, stated with the estimate: 10%); middle value at least 3.5-fold (0.55 log units) from the limit.
By their numbers in this assay, from the lowest: compounds 3, 2 and 1 (each within the scatter of the next). At a limit, above all of these: compound 4.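

In this assay, the carbon para to a large group no longer looks indifferent. Exchanging one halogen for another had left the number within the scatter, but methoxy gives an at least 3.6-fold higher number from compound 2 to compound 4 (0.55 log units; beyond the scatter), and in place of bromo it gives an at least 2.7-fold higher number from compound 1 to compound 4 (0.43 log units; beyond the scatter). So this carbon tolerates fluoro and bromo alike, yet compound 4 is clearly weaker with methoxy, and its value is a limit of the assay rather than a number, which leaves the full size of both steps unknown: the limit of > 100000 nM in this assay, at which 1 of the 4 values shown sits.

The compounds shown do not tell whether a hydroxy group, an amine or a longer chain such as ethoxy on this carbon would behave like methoxy or like the halogens. They also leave open whether methoxy has the same effect with thiophen-2-yl on the saturated ring carbon, as in compound 3.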